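The source may hold more compounds than are shown below. What is called first, only, known or untested is meant among the compounds shown, and "the series" means these compounds.

Measured compounds:
Compound 1 `O=C(c1cn[nH]c1)N1CCC(C(=O)N2N=CCC2c2ccccc2)CC1`: > 2.75 h
Compound 2 `CC(C)(C)C(=O)N1N=CCC1C1CCCCC1`: 0.0967 h

The study examined two compounds in an ADME assay on microsomes (Homo sapiens) for metabolic stability; on this read-out lower numbers stand for a shorter-lived compound and higher numbers for a longer-lived compound. For compound 1 the read-out in this assay is a limit of the assay rather than a number, recorded as > 2.75 h. Where compound 1 stands among the values is therefore set by the limit of > 2.75 h in this assay, at which 1 of the 2 values shown sits, so its exact half-life is unknown. Among the measured compounds shown here, compound 2, built on a different core, gives 0.0967 h in this assay; since no step between the two is measured, only the two values themselves can be compared.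

The unmeasured compound 3 `O=C(c1c[nH]nn1)N1CCC(C(=O)N2N=CCC2c2ccccc2)CC1` is related to compound 1 by a single change: 1H-1,2,3-triazol-4-yl in place of 1H-pyrazol-4-yl on a carbonyl carbon. For the measured compounds named here, no measured step covers this change, so the expected size of the step that the limit leaves unreadable from compound 1 to compound 3 is set at none beyond the usual scatter. On that basis compound 3 is estimated to give 3 h in this assay, with a range from 1 h to 8 h.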

Compound 3, half-life: > 2.75 h
Compound 3 ended at the assay's limit; the forecaster's own chance of this, stated with the estimate: 60%; the middle value lies beyond the limit too.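

No new step can be read between compound 1 and compound 3, since in this assay both rest at a limit of the assay: the limit of > 2.75 h in this assay, at which 2 of the 3 values shown sit.

As far as these compounds go, how long either half-life really runs, and whether 1H-1,2,3-triazol-4-yl in place of 1H-pyrazol-4-yl changes it at all, stays open.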